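A few compounds are considered here, and "the series" means these few. Any claim that something is new, unique, unknown or untested is made for them only; others in the source may bear on it.

Compound 1 `COc1cccnc1N1CCN(CCCCN2C(=O)SC3(CCCC3)C2=O)CC1` is reported in a functional assay on the whole organism for inhibition, with Rattus norvegicus as the target (on this read-out higher numbers stand for an effect only at larger amounts of compound and lower numbers for an effect already at smaller amounts), with < 57 mg/kg as a limit and not a number. Within the data shown here, compound 2 `COC(=O)c1cccnc1N1CCN(CCCCN2C(=O)SC3(CCCC3)C2=O)CC1` gives 50.2 mg/kg in this assay and holds the only actual number in the set, so it has no measured neighbour to be ranked against. Compound 3 `O=C1SC2(CCCC2)C(=O)N1CCCCN1CCN(c2ncccc2Cl)CC1` differs from compound 2 by chloro in place of methoxycarbonyl on an aromatic carbon and carries chloro in place of methoxycarbonyl on an aromatic carbon, ortho to a large group. Among the measured compounds shown here, one measured step bears on this change, a step that the limit leaves unreadable from compound 1 to compound 2 which also alters a group on an aromatic carbon, but it gives no size to carry over. The expectation therefore rests on compound 2 and its 50.2 mg/kg alone, with no shift beyond the scatter anticipated in either direction. The estimated step is a 1.1-fold lower number from compound 2 to compound 3 (0.05 log units; within the scatter) and it is expected to be small. Compound 3 is estimated at 45 mg/kg with an expected range from 15 mg/kg to 130 mg/kg in this assay as the measurement stands open.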

Compound 3, dose for half-maximal effect: 50 mg/kg
Compound 3: middle estimate off by 1.1-fold (0.05 log units), on the low side; the measured number falls inside the stated range.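

In this assay, among these compounds, chloro in place of methoxycarbonyl gives a 1.0-fold lower number from compound 2 to compound 3 (0.00 log units; within the scatter), the first readable step at this position on an aromatic carbon, ortho to a large group and two atoms from the ring nitrogen. Here a group of 4 heavy atoms with 2 hydrogen-bond acceptors and a single chlorine with none cannot be told apart on this read-out, which one actual number alone could not show. Compound 1 stands only as a limit, so neither step from it can be read: the limit of < 57 mg/kg in this assay, at which 1 of the 3 values shown sits.

Going by these compounds, whether an amine or a carboxylic acid at this position would move the number beyond the scatter stays open. With a single readable pair, the compounds shown also cannot say whether plain hydrogen there would give a different result.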